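Changing the aryl group on the ring nitrogen of compound 2

The compounds below may be only part of what the source reports. "The series", "measured", "known", "first", "only" and "open" are said of these compounds alone.

Measured so far:
compound 1, `N#CC1=C(N)Oc2c(c3nc4ccccc4nc3c3ccccc23)C12C(=O)N(Cc1cnnn1-c1cccc(Br)c1)c1ccccc12`, > 50000 nM
compound 2, `N#CC1=C(N)Oc2c(N)cc3nc4ccccc4nc3c2C12C(=O)N(Cc1cnnn1-c1ccc(Cl)cc1)c1ccccc12`, > 50000 nM

Both values come from a functional assay on MCF7 cells (Homo sapiens) for antiproliferative activity, read by MTT assay, with a stated time of 48 h; on this read-out higher numbers stand for weaker inhibition and lower numbers for stronger inhibition. For compound 1 the value > 50000 nM is a limit of the assay and not a number. For compound 2 the value > 50000 nM is likewise a limit and not a number. For the measured compounds named here, compound 2 therefore stands at the edge of what the assay can report, and the only other value shown sits there too: the limit of > 50000 nM in this assay, at which 2 of the 2 values shown sit. Going by the values given here, no measured pair differs in just one place, so no measured step is available to learn from. Compound 3, `CCc1cccc(C)c1-n1nncc1CN1C(=O)C2(C(C#N)=C(N)Oc3c(N)cc4nc5ccccc5nc4c32)c2ccccc21`, is not yet measured. It differs from compound 2 in one group: 2-ethyl-6-methylphenyl in place of 4-chlorophenyl on an aromatic nitrogen. The step that the limit leaves unreadable from compound 2 to compound 3 is expected to be none beyond the scatter, since the starting point is a limit. The estimate for compound 3 in this assay is 60000 nM, with a range from 15000 nM to 250000 nM, and a limit is again the most likely outcome.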

Compound 3, half-maximal inhibitory concentration: > 50000 nM
Compound 3: no number, only a limit; the forecaster's own chance of this, stated with the estimate: 80%; the middle value is on the limit's open side.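

For the compounds shown here, compound 2 and compound 3 both end at a limit of the assay and not at a number, so no step between them can be read. How strongly any of the compounds shown inhibits remains open, as all of them stop at the same edge: the limit of > 50000 nM in this assay, at which 3 of the 3 values shown sit.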